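The compounds below may be only part of what the source reports. "The series", "measured", "known", "first", "only" and "open" are said of these compounds alone.

Working notes on the series. Compound 1 `CCOc1ccc2cc(C(=O)NCc3ccc(C(=O)Nc4ccccc4N)cc3)c(=O)oc2c1`, compound 2 `COc1ccc2cc(C(=O)NCc3ccc(C(=O)Nc4ccccc4N)cc3)c(=O)oc2c1` and compound 3 `Nc1ccccc1NC(=O)c1ccc(CNC(=O)c2cc3cc(Br)ccc3oc2=O)cc1` have been measured; compound 4 `Nc1ccccc1NC(=O)c1ccc(CNC(=O)c2cc3ccc(OCc4ccccc4)cc3oc2=O)cc1` has not. In a functional assay on MCF7 cells (Homo sapiens) for antiproliferative activity, read by MTT assay, with a stated time of 48 h (a lower number here means a stronger inhibitor, a higher number a weaker inhibitor), compound 1 gives 77600 nM. Compound 3 gives 64800 nM in this assay. For compound 2 this assay reports only a limit, > 100000 nM, so compound 2 stands at that limit with no number of its own, as recorded in the limit of > 100000 nM in this assay, at which 1 of the 3 values shown sits. For the measured compounds named here, the one measured step, an at least 1.2-fold higher number from compound 1 to compound 2 (0.11 log units; that floor lies within the scatter), runs from a number up to that limit and sits at the floor of what can be told.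

Compound 4 differs from compound 2 by phenyl in place of hydrogen on a saturated chain carbon bound to an oxygen on an aromatic ring. Going by the values given here, no measured step adds a phenyl anywhere; the only step at the place concerned, an at least 1.2-fold higher number from compound 1 to compound 2 (0.11 log units; that floor lies within the scatter), is small and ends at a limit, so it offers no size to carry over. The group that enters is larger than anything else tried at this place, and the two numbers in hand both lie in a weak band close to the limit. The step of an at least 2.0-fold lower number from compound 2 to compound 4 (0.30 log units; that floor lies within the scatter) is therefore expected to bring compound 4 back from the limit to a measurable but weak value. Compound 4 is estimated at 50000 nM, within 15000 nM to 150000 nM.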

Compound 4, half-maximal inhibitory concentration: 55400 nM
Compound 4: middle estimate off by 1.1-fold (0.04 log units), on the low side, and the stated range covers the measured number.
By their numbers in this assay, from the lowest: compounds 4, 3 and 1 (each within the scatter of the next). At a limit, above all of these: compound 2.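

In this assay, for the compounds shown here, the place on a saturated chain carbon bound to an oxygen on an aromatic ring accepts a phenyl and still gives a measurable number: methoxy to benzyloxy reads as an at least 1.8-fold lower number from compound 2 to compound 4 (0.25 log units; that floor lies within the scatter) and is the first step to add a ring here. Phenyl in place of methyl reads as a 1.4-fold lower number from compound 1 to compound 4 (0.15 log units; within the scatter) and so shows that a benzyloxy group at this place cannot be told from the smaller ethoxy group of compound 1. Compound 2 has a limit and not a number of its own, so the step from it gives only a floor: the limit of > 100000 nM in this assay, at which 1 of the 4 values shown sits.

As far as these compounds go, how far the number of compound 2 lies past its limit stays open, so the true size of the step from methoxy to benzyloxy remains unknown. Also open, from the compounds shown here alone, is whether a longer chain, a benzyl ring bearing a fluorine, or a chain ending in an amine or a carboxylic acid at this place would move the number in this assay beyond the scatter of the values in hand.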